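Ester to acid on a cell-growth series

The source may hold more compounds than are shown below. What is called first, only, known or untested is meant among the compounds shown, and "the series" means these compounds.

Measured so far:
- Compound 1 `COc1ccc2c(c1)c(/C=C/C(=O)c1ccncc1)cn2C`: 52%
- Compound 2 `Cc1[nH]c2ccc(O)cc2c1/C=C/C(=O)c1ccncc1`: 43%
- Compound 3 `COC(=O)c1ccc(COc2ccc3[nH]c(C)c(/C=C/C(=O)c4ccncc4)c3c2)cc1`: 76%

All three compounds share a core and were tested in a functional assay on U-251 cells (Homo sapiens) for inhibition, read by colony formation, with stated times of 48 h and 2 weeks, tested at 10 uM; a lower number here means less inhibition, a higher number more inhibition at the concentration tested (going by the name of the read-out). Compound 3 gives the highest of the three numbers in this assay. Its nearest neighbour is compound 1, whose number is lower by an amount beyond the usual scatter, and compound 2 lies further below it, also beyond the scatter. So compound 3 shows, on these numbers, the highest inhibition in this assay of the three.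

Compound 4 `Cc1[nH]c2ccc(OCc3ccc(C(=O)O)cc3)cc2c1/C=C/C(=O)c1ccncc1` has not yet been measured. It differs from compound 3 in one place: hydrogen in place of methyl on an oxygen next to a carbonyl group. Put in other words, a methoxycarbonyl group becomes a carboxy group, so the 4-(methoxycarbonyl)phenyl group of compound 3 becomes a 4-carboxyphenyl group in compound 4.

For the measured compounds named here, no pair among the measured compounds shows this kind of change, so there is no measured step to lean on. For compound 4 the expected step in this assay, from compound 3, is estimated as a modest fall, a number 16 percentage points lower from compound 3 to compound 4 (beyond the scatter), close to the edge of the scatter. Compound 4 is therefore estimated to give 60%, with a likely range from 35% to 80%.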

Compound 4, a percentage reported as inhibition, at one concentration (the size of the read-out at that concentration, not a potency): 71%
For compound 4 the middle estimate is 11 percentage points below the measured one, within the range that was stated.
By their numbers in this assay, from the lowest: compounds 2 and 1 (each within the scatter of the next); then compounds 4 and 3 (each within the scatter of the next).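

In this assay, putting hydrogen in place of the methyl on the ester oxygen turns the methoxycarbonyl into a carboxy group and gives a number 5 percentage points lower from compound 3 to compound 4 (within the scatter), so at this position these two end groups cannot be told apart on these numbers. Adding 4-carboxybenzyl in place of hydrogen on the oxygen on the aromatic ring gives a number 28 percentage points higher from compound 2 to compound 4 (beyond the scatter), which is the first direct sign in this set that what sits on that oxygen can change the read-out. Nothing shown gives a reason for either step.

The compounds shown leave open how a primary amide or a tetrazole would read in place of the carboxy group, and whether a longer chain between the ring oxygen and the 4-carboxyphenyl group would keep the same level of inhibition. Compound 1 differs from the others in more than one place, so it cannot be used to judge any single change, and readings at one concentration leave the potency of all these compounds unknown.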